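The source may hold more compounds than are shown below. What is called first, only, known or untested is meant among the compounds shown, and "the series" means these compounds.

Compound 1 `Cc1ccc2oc(-c3cccc(C[C@H](O)/C=C/[C@H]4CCC(=O)N4CCSc4nc(C(=O)O)cs4)c3)nc2c1` and compound 2 `Cc1cccc2oc(-c3cccc(C[C@H](O)/C=C/[C@H]4CCC(=O)N4CCSc4nc(C(=O)O)cs4)c3)nc12` share one core and differ only in the placement of a single methyl on the 1,3-benzoxazol-2-yl group. In an assay on CHO cells for displacement of a labelled ligand from prostaglandin E2 receptor EP4 subtype (Mus musculus), read by scintillation counting, with a stated time of 60 min (on this read-out higher numbers stand for weaker inhibition and lower numbers for stronger inhibition), compound 1 gives 0.21 nM. In this assay compound 2 gives 0.21 nM, so compound 2 stands level with compound 1. The step of no change at the digits printed from compound 1 to compound 2 (within the scatter) shows that relocating that methyl left the reading where it was. Compound 3 `Cc1cc(C)c2oc(-c3cccc(C[C@H](O)/C=C/[C@H]4CCC(=O)N4CCSc4nc(C(=O)O)cs4)c3)nc2c1` carries 5,7-dimethyl-1,3-benzoxazol-2-yl in place of 4-methyl-1,3-benzoxazol-2-yl on an aromatic carbon, a second methyl joining the same group. Going by the values given here, the only measured step that bears on this is the one from compound 1 to compound 2, which stayed within the scatter; it too concerned methyl placement on that group. The expectation is therefore a step of a 1.2-fold higher number from compound 2 to compound 3 (0.08 log units; within the scatter) in this assay of no size beyond the scatter, in no particular direction. Compound 3 is estimated at 0.25 nM, with a range from 0.1 nM to 0.6 nM.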

Compound 3, inhibition constant: 0.15 nM
Estimate against measurement, compound 3: 1.7-fold (0.22 log units) above, and the stated range covers the measured number.
By their numbers in this assay, from the lowest: compounds 3, 1 and 2 (each within the scatter of the next).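

Putting a methyl in place of hydrogen on an aromatic carbon of the 5-methyl-1,3-benzoxazol-2-yl group gives a 1.4-fold lower number from compound 1 to compound 3 (0.15 log units; within the scatter) in this assay, so this group can take an added methyl, not just a moved one, without the reading leaving the scatter. Replacing 4-methyl-1,3-benzoxazol-2-yl with 5,7-dimethyl-1,3-benzoxazol-2-yl gives the same picture, with a 1.4-fold lower number from compound 2 to compound 3 (0.15 log units; within the scatter). No measurement here accounts for this flat reading.

On these data alone, all three compounds carry only methyl on this group, so the effect of a chlorine, a methoxy group or an amine in its place remains open. Also open, as far as these compounds go, is how the plain 1,3-benzoxazol-2-yl group, with no methyl at all, would read.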